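The compounds below may be only part of what the source reports. "The series", "measured", "known", "first", "only" and "open" are said of these compounds alone.

Measured so far in an ADME assay on cells (Fibroblast, Homo sapiens) for cytotoxicity, with a stated time of 48 h; on this read-out higher numbers stand for weaker inhibition and lower numbers for stronger inhibition:
compound 1, `O=[N+]([O-])c1ccc(CN2CCC(n3cc(CC(OCc4cc(-c5ccccc5)no4)c4ccc(Br)cc4)nn3)CC2)cc1`, gives > 25000 nM;
compound 2, `O=[N+]([O-])c1ccc(CN2CCC(n3cc(CC(OCc4cc(-c5ccc(Br)cc5)no4)c4ccc(Br)cc4)nn3)CC2)cc1`, gives > 25000 nM;
compound 3, `N#Cc1ccc(-c2cc(COC(Cc3cn(C4CCN(Cc5ccc([N+](=O)[O-])cc5)CC4)nn3)c3ccc(Br)cc3)on2)cc1`, gives > 25000 nM.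

The value of compound 1 is a limit of this assay, not a number. The value of compound 2 is likewise a limit. The value of compound 3 is a limit too, so compound 3 stands at the same limit as the other two. For the measured compounds named here, none of the measured steps can be read in size: a step that the two limits leave unreadable from compound 1 to compound 2; a step that the two limits leave unreadable from compound 1 to compound 3; a step that the two limits leave unreadable from compound 2 to compound 3. Going by the values given here, the only evidence is the limit of > 25000 nM in this assay, at which 3 of the 3 values shown sit.

Compound 4, `N#Cc1cccc(-c2cc(COC(Cc3cn(C4CCN(Cc5ccc([N+](=O)[O-])cc5)CC4)nn3)c3ccc(Br)cc3)on2)c1`, differs from compound 3 by 3-cyanophenyl in place of 4-cyanophenyl on an aromatic carbon. Because (the limit of > 25000 nM in this assay, at which 3 of the 3 values shown sit), the expectation for this step is a step that the limit leaves unreadable from compound 3 to compound 4, with no change beyond the scatter. Compound 4 is estimated at 30000 nM, from 12000 nM to 100000 nM, most likely reported again only as a limit.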

Compound 4, half-maximal inhibitory concentration: > 25000 nM
Compound 4: a limit, no number; the forecaster's own chance of this, stated with the estimate: 85%; the middle value is on the limit's open side.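

Compound 4 also gives only a limit, so its steps from compound 1, compound 2 and compound 3 cannot be read in size: the limit of > 25000 nM in this assay, at which 4 of the 4 values shown sit. The compounds shown leave open what actual value any of them has in this assay, and so whether 3-cyanophenyl and 4-cyanophenyl differ at all.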